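This account rests on a few compounds, and the source may have more. Where it says the series, first, only, none or still open, it means among the compounds named here.

Measured in a functional assay on RAW264.7 cells (Mus musculus) for inhibition, read by Griess assay, with stated times of 1 h and 24 h; on this read-out lower numbers stand for stronger inhibition and higher numbers for weaker inhibition:
Compound 1 `CCCCOc1ccc(C(O)C2OC(=O)c3c(OC)cc(OC)cc32)cc1`: 1800 nM
Compound 2 `CCOCCOc1ccc(C(O)C2OC(=O)c3c(OC)cc(OC)cc32)cc1`: > 10000 nM

Compound 2 stands at > 10000 nM, which is a limit of this assay and not a number. Compound 3 `COc1cc(OC)c2c(c1)C(C(O)c1ccc(OCc3ccc(C)cc3)cc1)OC2=O` has 4-methylphenyl in place of ethoxymethyl on a saturated chain carbon bound to an oxygen on an aromatic ring. For the measured compounds named here, only one measured step bears on this change: an at least 5.5-fold higher number from compound 1 to compound 2 (0.74 log units; beyond the scatter), where an ethoxy entered the same chain and the number rose. Compound 3 no longer carries that ethoxy, so a move back towards compound 1 is expected, though a new ring enters untested. The expected change is an at least 2.5-fold lower number from compound 2 to compound 3 (0.39 log units; beyond the scatter), towards a lower number. Estimated for compound 3 is 4000 nM, with an expected range of 1200 nM to 13000 nM.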

Compound 3, half-maximal inhibitory concentration: 3120 nM
The estimate for compound 3 lay 1.3-fold (0.11 log units) above the measured number; the measured number falls inside the stated range.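

With 4-methylphenyl in place of ethoxymethyl, this assay shows an at least 3.2-fold lower number from compound 2 to compound 3 (0.50 log units; beyond the scatter), so this chain position accepts an aromatic ring without the loss seen for compound 2. Compound 2 stands at a limit of the assay and not at a number: the limit of > 10000 nM in this assay, at which 1 of the 3 values shown sits.

Set against propyl, 4-methylphenyl gives a 1.7-fold higher number from compound 1 to compound 3 (0.24 log units; within the scatter), so compound 1 and compound 3 cannot be told apart here.

From the compounds shown here alone, whether other rings behave like 4-methylphenyl remains open. So does the effect of an amine, a carboxylic acid or a longer chain on the same saturated chain carbon.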